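The source may hold more compounds than are shown below. What is called first, only, known or untested is meant among the compounds shown, and "the series" means these compounds.

Measured compounds:
compound 1 `O=C1C=CC(=O)N1Cc1ccc(Oc2ccccc2)cc1` gives 4900 nM in an assay on microsomes from brain (strain Sprague-Dawley) for inhibition of Fatty-acid amide hydrolase 1 (Rattus norvegicus), read by HPLC, with stated times of 10 min and 45 min; a lower number here means a stronger inhibitor, a higher number a weaker inhibitor
compound 2 `CN(C)C(=O)n1nnc(-c2ccc(Oc3ccc(Cl)cc3)cc2)n1` gives 16 nM in this assay

Of the two measured compounds, compound 2 has the lower number, and the gap to compound 1 is far beyond the scatter of the measurement. Compound 3 `CN(C)C(=O)n1nnc(-c2ccc(Oc3ccc(Cl)c(Cl)c3)cc2)n1` has not been measured. It differs from compound 2 in one place: chloro in place of hydrogen on an aromatic carbon, in words, chloro in place of hydrogen on an aromatic carbon. For the measured compounds named here, no pair of measured compounds differs by such a change, so nothing in the numbers shows how large a step to expect. The expected step from compound 2 to compound 3 is a 1.3-fold lower number from compound 2 to compound 3 (0.12 log units; within the scatter), that is, no step beyond the scatter in either direction. Compound 3 is therefore estimated at 12 nM in this assay, with a range from 4 nM to 40 nM.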

Compound 3, half-maximal inhibitory concentration: 11 nM
Compound 3: middle estimate off by 1.1-fold (0.04 log units), on the high side; low and high end bracket the measured number.
By their numbers in this assay, from the lowest: compounds 3 and 2 (each within the scatter of the next); then compound 1.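

In this assay, replacing 4-chlorophenyl with 3,4-dichlorophenyl gives a 1.5-fold lower number from compound 2 to compound 3 (0.16 log units; within the scatter). This is the first reading of chloro in place of hydrogen among these compounds, and it shows that a chloro group can stand on this aromatic carbon, ortho to the existing chloro group, without a step beyond the scatter in either direction. Nothing measured here offers an explanation for this result.

The compounds shown leave open whether a methoxy group, a trifluoromethyl group or an amine on the same carbon would also stay within the scatter of compound 2. They also leave open whether chloro on this carbon would give a similar step if the existing chloro group were absent.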